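Opening a ring in a series of weak inhibitors

The source may report more compounds than this note shows. Statements on the series, on what has been measured and on what is new or still open speak of the compounds shown alone.

Of the compounds shown here, three sharing one core have been tested in a functional assay on MCF7 cells (Homo sapiens) for antiproliferative activity, read by sulforhodamine B assay, with a stated time of 48 h; a higher number here means a weaker inhibitor, a lower number a stronger inhibitor. Compound 1 `COc1cc(NC(C)CCCN2C(=O)[C@H](C)NC2(C)C)c2ncccc2c1` gives 42300 nM in this assay. For compound 2 `COc1cc(NC(C)CCCN2C(=O)CN(C(C)=O)C2(C)C)c2ncccc2c1` this assay reports only a limit, > 100000 nM. Compound 3 `COc1cc(NC(C)CCCNC(=O)CN2C(=O)[C@H](C)NC2(C)C)c2ncccc2c1` gives 38300 nM in this assay, a number that sits within the usual scatter of the number for compound 1, so the two cannot be told apart; among the results that are numbers, compound 3 stands at the low end.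

Compound 4 `COc1cc(NC(C)CCCNC(=O)CNC(=O)[C@H](C)N)c2ncccc2c1` has not yet been measured. It differs from compound 3 by ((1-aminoethyl)carbonyl)amino in place of 2,2,4-trimethyl-5-oxoimidazolidin-1-yl on a saturated chain carbon bound to a carbonyl carbon: the five-membered ring is opened and a short chain takes its place. For the measured compounds named here, no pair of measured compounds shows what such a change does in this assay. Given that compound 3 gives 38300 nM, compound 4 is expected to stay in the same weak region, with the step of a 1.0-fold higher number from compound 3 to compound 4 (0.02 log units; within the scatter) expected to lie within the scatter. The estimate for compound 4 is 40000 nM, ranging from 12000 nM to 130000 nM.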

Compound 4, half-maximal inhibitory concentration: 21300 nM
Compound 4: middle estimate off by 1.9-fold (0.27 log units), on the high side, within the range that was stated.
By their numbers in this assay, from the lowest: compounds 4, 3 and 1 (each within the scatter of the next). At a limit, above all of these: compound 2.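

In this assay, opening the ring gives a 1.8-fold lower number from compound 3 to compound 4 (0.25 log units; within the scatter), so compound 3 and compound 4 cannot be told apart. For the compounds shown here, this is the first measured pair that differs in this one place, and it shows that ((1-aminoethyl)carbonyl)amino, which has no ring, can stand in place of 2,2,4-trimethyl-5-oxoimidazolidin-1-yl on a saturated chain carbon bound to a carbonyl carbon and leave the number within the scatter. Nothing in the data shown explains this result.

From the compounds shown here alone, with a single pair, it remains unknown whether the same ring opening would give a similar result on another member of the series. Going by these compounds, it is also open whether a carboxylic acid in place of the amine, or a longer chain, would give a number beyond the scatter of compound 4.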